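A few compounds are considered here, and "the series" means these few. Any claim that something is new, unique, unknown or untested is made for them only; others in the source may bear on it.

Measured compounds:
- compound 1: `O=S(=O)(Nc1ccc2oc(-c3ccccc3)nc2c1)c1ccccc1O`, 33000 nM
- compound 2: `O=S(=O)(Nc1ccc(-c2nc3ccccc3o2)cc1)c1ccccc1O`, > 100000 nM

In an ADME assay on HEK293 cells (Homo sapiens) for cytotoxicity, read by resazurin assay, with a stated time of 48 h (a lower number here means that less compound is tolerated, a higher number that more compound is tolerated), compound 1 gives 33000 nM. Among the values shown for this series it is the only one that is a number. For compound 2 the result in this assay is a limit, > 100000 nM, not a number (the limit of > 100000 nM in this assay, at which 1 of the 2 values shown sits). Among the compounds with values here, compound 1 and compound 2 differ in more than one place, so no single step connects them and their two values are stated side by side without further reading.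

Compound 3 `COc1cccc(S(=O)(=O)Nc2ccc3oc(-c4ccccc4)nc3c2)c1` is still to be measured in this assay. It differs from compound 1 in one place: 3-methoxyphenyl in place of 2-hydroxyphenyl on a sulfonyl sulfur. Within the data shown here, no pair of measured compounds shares this change, so its size cannot be taken from the data. Such a change on the sulfonyl sulfur is expected to leave the tolerated concentration close to that of compound 1, with a step of a 1.2-fold higher number from compound 1 to compound 3 (0.08 log units; within the scatter) that stays within the usual scatter. Compound 3 is therefore estimated at 40000 nM in this assay, with a plausible range from 15000 nM to 100000 nM, and a real chance that only a limit is reported.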

Compound 3, half-maximal cytotoxic concentration: 63000 nM
Beside the measured number, compound 3's estimate is 1.6-fold (0.20 log units) below it, and the stated range covers the measured number.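

In this assay, 3-methoxyphenyl in place of 2-hydroxyphenyl on the sulfonyl sulfur, a change that also takes the count of hydrogen-bond donors on this group from 1 to 0, gives a 1.9-fold higher number from compound 1 to compound 3 (0.28 log units; within the scatter). This single step shows that this position accepts one change of group without a shift beyond the scatter, and the result for compound 3 is still a number. The one limit in the series belongs to compound 2, and it is a limit, not a number: the limit of > 100000 nM in this assay, at which 1 of the 3 values shown sits.

The step changes the oxygen-bearing group and its place on the ring together, so the two contributions cannot be read apart; 2-methoxyphenyl and 3-hydroxyphenyl on the sulfonyl sulfur would each separate them. Also open, on these data alone, is whether a group of another kind on that ring, such as an amine or a carboxylic acid, would move the tolerated concentration beyond the scatter, and whether the same change would behave alike on the core of compound 2.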